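A few compounds are considered here, and "the series" means these few. Any claim that something is new, unique, unknown or untested is made for them only; others in the source may bear on it.

Of the compounds shown here, three built on one shared core have been tested in a functional assay on HepG2 cells (Homo sapiens) for cytotoxicity, read by MTT assay, with a stated time of 72 h; on this read-out lower numbers stand for stronger inhibition and higher numbers for weaker inhibition. Compound 1 `Cc1cc(=O)n(-c2ccccc2C(F)(F)F)nc1C(=O)Nc1ccc(Oc2ncnc3ccsc23)cc1` gives 9230 nM, compound 3 `Cc1cc(=O)n(-c2ccc(F)c(F)c2)nc1C(=O)Nc1ccc(Oc2ncnc3ccsc23)cc1` gives 9230 nM, and compound 2 `Cc1ccc(-n2nc(C(=O)Nc3ccc(Oc4ncnc5ccsc45)cc3)c(C)cc2=O)cc1` gives 25000 nM, the highest of the three numbers and so the weakest inhibition of cell growth among them. Every change measured so far sits on the aromatic nitrogen: a 2.7-fold higher number from compound 1 to compound 2 (0.43 log units; beyond the scatter), a 2.7-fold lower number from compound 2 to compound 3 (0.43 log units; beyond the scatter), while no change at the digits printed from compound 1 to compound 3 (within the scatter). Compound 4 `Cc1ccc(-n2nc(C(=O)Nc3ccc(Oc4ncnc5ccsc45)c(F)c3)c(C)cc2=O)cc1` has not yet been measured. It differs from compound 2 in another part of the core: fluoro in place of hydrogen on an aromatic carbon. Within the data shown here, no measured pair touches this part of the molecule, so none of the three measured steps bears directly on the change; they show only that changes elsewhere on this core shift the read-out by a modest amount or not at all. Among the measured compounds shown here, with no direct precedent, the step from compound 2 to compound 4 is expected to be no change at the digits printed from compound 2 to compound 4 (within the scatter), that is, nothing beyond the usual scatter. Compound 4 is therefore estimated at 25000 nM in this assay, with a likely range from 9000 nM to 70000 nM.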

Compound 4, half-maximal inhibitory concentration: 17300 nM
Estimate against measurement, compound 4: 1.4-fold (0.16 log units) above; measured number inside the range.
By their numbers in this assay, from the lowest: compounds 1, 3, 4 and 2 (each within the scatter of the next, the first and the last beyond it).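

In this assay, among these compounds, the first measured change at this part of the molecule, fluoro in place of hydrogen on an aromatic carbon, gives a 1.4-fold lower number from compound 2 to compound 4 (0.16 log units; within the scatter). The new atom sits ortho to a large group and meta to a large group, and even so compound 2 and compound 4 cannot be told apart on this read-out, so with the 4-methylphenyl group on the aromatic nitrogen this carbon tolerates a fluoro without a measurable shift in cell growth inhibition. No measurement at hand explains this result.

Fluoro adds only 1 heavy atom, so the compounds shown leave open whether a chloro, a methoxy or an amine on the same carbon would also leave the number within the scatter, or would move it clearly in either direction. They also leave open whether the same fluoro would give a similar result alongside the 2-(trifluoromethyl)phenyl group of compound 1 or the 3,4-difluorophenyl group of compound 3, since it has been seen here on a single background.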